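Amino for Nitro on a Shifted Core

A few compounds are considered here, and "the series" means these few. Any claim that something is new, unique, unknown or untested is made for them only; others in the source may bear on it.

Compound 1 `COc1ccc(/C=C/S(=O)(=O)Cc2ccc(OC)c([N+](=O)[O-])c2)cc1` and compound 2 `COc1ccc(/C=C/S(=O)(=O)Cc2ccc(OC)c(N)c2)cc1` share one core and differ at a single point: amino in place of nitro on an aromatic carbon. In a functional assay on DU-145 cells (Homo sapiens) for cytotoxicity, read by trypan blue exclusion, with a stated time of 96 h (on this read-out lower numbers stand for stronger inhibition and higher numbers for weaker inhibition), compound 1 gives 25000 nM, while compound 2 gives 2500 nM, which is a 10-fold lower number from compound 1 to compound 2 (1.00 log units; beyond the scatter). Compound 3 `COc1ccc(CS(=O)(=O)/C=C/c2c(OC)cccc2OC)cc1[N+](=O)[O-]` carries a different core; how its core differs from that of compound 1 is not broken down here. In this assay compound 3 gives 20000 nM. Compound 4 `COc1ccc(CS(=O)(=O)/C=C/c2c(OC)cccc2OC)cc1N` has not yet been measured and differs from compound 3 by the same change: amino in place of nitro on an aromatic carbon. Because the earlier step was a 10-fold lower number from compound 1 to compound 2 (1.00 log units; beyond the scatter), a step of similar size is expected here, an 8.0-fold lower number from compound 3 to compound 4 (0.90 log units; beyond the scatter). Compound 4 is therefore estimated at 2500 nM in this assay, most likely between 800 nM and 8000 nM.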

Compound 4, half-maximal inhibitory concentration: 50 nM
Compound 4: middle estimate off by 50-fold (1.70 log units), on the high side, and the stated range ends above it.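

On the core of compound 3, amino in place of nitro gives a 400-fold lower number from compound 3 to compound 4 (2.60 log units; beyond the scatter) in this assay. The direction of the change carried over from the core of compound 1, but its size did not: the same change on two cores in this assay, a 10-fold lower number (1.00 log units; beyond the scatter) from compound 1 to compound 2 and a 400-fold lower number (2.60 log units; beyond the scatter) from compound 3 to compound 4, 40-fold (1.60 log units) apart, beyond the scatter of two such steps. These two pairs do not explain the gap between the steps, and two cores cannot show how the same change would behave on a third.

The compounds shown leave open whether another group on that aromatic carbon, such as a hydroxyl group or an acetylated amine, would keep a number as low as that of compound 4. They also leave open whether the amino group would give a similar step on other cores in this series.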